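The compounds below may be only part of what the source reports. "The series", "measured", "known", "first", "only" and "open" are said of these compounds alone.

Measured in an ADME assay on WI-38 cells (Homo sapiens) for cytotoxicity, read by MTT assay, with a stated time of 48 h; on this read-out lower numbers stand for stronger inhibition and higher numbers for weaker inhibition:
- compound 1 `CC(C)(Oc1ccc(Cl)cc1)C(=O)NCCOC(=S)Nc1ccc(F)cc1`: > 800000 nM
- compound 2 `O=C(NCCOC(=S)Nc1ccc(F)cc1)c1cccnc1`: > 800000 nM

Neither compound has a numerical value on this read-out, and the limit of > 800000 nM in this assay, at which 2 of the 2 values shown sit, is the only mark reached so far. Compound 1 gives > 800000 nM, which is a limit of the assay and not a number. On these data alone, compound 2 likewise gives > 800000 nM, and this too is a limit and not a number, so its true position on the scale remains open.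

The next compound is compound 3 `O=C(NCCOC(=S)Nc1ccccc1)c1cccnc1`. It has hydrogen in place of fluoro on an aromatic carbon, para to a large group, so that 4-fluorophenyl becomes phenyl (hydrogen in place of fluoro on an aromatic carbon). Among the measured compounds shown here, no measured pair yet shows what a single change does in this assay, so the expectation rests only on the limit shared by compound 1 and compound 2. No shift beyond the usual scatter is expected, in either direction, and the estimated change is a number no higher from compound 2 to compound 3 (the limit leaves the size open). The assay is expected to report only a limit again. For compound 3 the expected value is 800000 nM, with an estimated range of 300000 nM to 1600000 nM.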

Compound 3, half-maximal inhibitory concentration: > 800000 nM
Compound 3: no number, only a limit (the forecaster's own chance of this, stated with the estimate: 80%); the middle value lies on the limit itself.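

In this assay compound 3 gives > 800000 nM, which is a limit of the assay and not a number. Compound 2 also has only a limit, so the change from 4-fluorophenyl to phenyl between compound 2 and compound 3 cannot be read: the limit of > 800000 nM in this assay, at which 3 of the 3 values shown sit.

The compounds shown leave open where the true values of compound 1, compound 2 and compound 3 lie on the scale, and whether this change has any effect.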